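Swapping Methoxy for Trifluoromethyl on a Lone Measured Compound

This account rests on a few compounds, and the source may have more. Where it says the series, first, only, none or still open, it means among the compounds named here.

Among the measured compounds shown here, only three compounds have been tested so far in a functional assay on MDA-MB-435 cells (Homo sapiens) for cytotoxicity, read by MTT assay, with a stated time of 72 h; a lower number here means a stronger inhibitor, a higher number a weaker inhibitor. Compound 1 `CS(=O)(=O)Oc1c(C(=O)NCc2ccc(F)cc2)nc(Br)c2cccnc12` gives > 20000 nM, which is a limit of the assay and not a number. Compound 3 `C[C@H](CO)Nc1nc(C(=O)NCc2ccc(F)cc2)c(O)c2ncccc12` gives > 20000 nM, and this too is a limit. For the measured compounds named here, compound 2 `COc1cccc(CNC(=O)c2nc(Br)c3cccnc3c2N[C@H]2CC[C@H](N)CC2)c1` gives 7000 nM, the only actual number among the three, so it is the one firm reference point available.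

The next compound to be tested is compound 4 `N[C@H]1CC[C@H](Nc2c(C(=O)NCc3cccc(C(F)(F)F)c3)nc(Br)c3cccnc23)CC1`, which differs from compound 2 in one place: trifluoromethyl in place of methoxy on an aromatic carbon. The trifluoromethyl takes the place of the methoxy on an aromatic carbon, meta to a large group. Going by the values given here, no pair of tested compounds shows what a swap of this kind does, so there is no measured step to lean on, and the expectation has to stay modest. No change beyond the usual scatter is expected in this assay, and no direction can be favoured with any confidence. The expected size of the change is a 1.2-fold lower number from compound 2 to compound 4 (0.07 log units; within the scatter). For compound 4 the estimated value is 6000 nM, with an expected range from 2500 nM to 15000 nM.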

Compound 4, half-maximal inhibitory concentration: 4200 nM
Beside the measured number, compound 4's estimate is 1.4-fold (0.15 log units) above it; the measured number falls inside the stated range.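

Replacing 3-methoxybenzyl with 3-(trifluoromethyl)benzyl gives a 1.7-fold lower number from compound 2 to compound 4 (0.22 log units; within the scatter) in this assay, so the two compounds cannot be told apart in this assay. Among the compounds shown here, this is the first measured step at this position, and it gives a second real number to set beside the single one available before. The entering group has more heavy atoms than methoxy and no hydrogen-bond acceptor, yet neither difference produces a change beyond the scatter in this pair.

On these data alone, whether other groups at this place, such as an amine or a carboxylic acid, would behave the same way remains open. Compound 1 and compound 3 differ from this pair in more than one place, so they cannot show how much the rest of the structure matters, and their values offer no measured step: the limit of > 20000 nM in this assay, at which 2 of the 4 values shown sit.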